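Butoxy to amino on the shared core

A few compounds are considered here, and "the series" means these few. Any claim that something is new, unique, unknown or untested is made for them only; others in the source may bear on it.

In a functional assay on A549 cells (Homo sapiens) for antiproliferative activity, read by MTT assay, with a stated time of 48 h (a lower number here means a stronger inhibitor, a higher number a weaker inhibitor), compound 1 `CCCCOc1ccc(C(=O)/C=C/c2c(/C=C/c3ccc(OC)cc3)cc(OC)cc2OC)cc1` gives 8.7 ug/mL, compound 2 `COc1ccc(/C=C/c2cc(OC)cc(OC)c2/C=C/C(=O)c2ccc(Br)cc2)cc1` gives 8.3 ug/mL and compound 3 `COc1ccc(/C=C/c2cc(OC)cc(OC)c2/C=C/C(=O)c2ccc(C(F)(F)F)cc2)cc1` gives 7.8 ug/mL. Compound 1 therefore stands level with the other two, and all of its gaps to them lie within the scatter.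

The unmeasured compound 4 `COc1ccc(/C=C/c2cc(OC)cc(OC)c2/C=C/C(=O)c2ccc(N)cc2)cc1` keeps the core of compound 1 and differs in one place: amino in place of butoxy on an aromatic carbon. This is amino in place of butoxy on an aromatic carbon, para to a large group, or 4-butoxyphenyl to 4-aminophenyl when cut one bond further out.

Within the data shown here, three measured steps bear on this place. Bromo in place of butoxy gives a 1.0-fold lower number from compound 1 to compound 2 (0.02 log units; within the scatter), trifluoromethyl in place of butoxy gives a 1.1-fold lower number from compound 1 to compound 3 (0.05 log units; within the scatter), and trifluoromethyl in place of bromo gives a 1.1-fold lower number from compound 2 to compound 3 (0.03 log units; within the scatter). All three lie within the scatter. Amino itself has not been measured at this place, so these steps are only indirect guidance, and they favour no direction. On their size, no step beyond the scatter is expected in this assay. The estimated step is a 1.1-fold lower number from compound 1 to compound 4 (0.04 log units; within the scatter). The estimated value for compound 4 is 8 ug/mL, with an expected range of 4.5 ug/mL to 14 ug/mL.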

Compound 4, half-maximal inhibitory concentration: 3.8 ug/mL
Beside the measured number, compound 4's estimate is 2.1-fold (0.32 log units) above it, outside the stated range (below it).
By their numbers in this assay, from the lowest: compound 4; then compounds 3, 2 and 1 (each within the scatter of the next).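

In this assay, butoxy, bromo and trifluoromethyl had left this aromatic carbon, para to a large group, looking insensitive to substitution, since all three stood level within the scatter. Amino shows that the position can respond after all, with a 2.3-fold lower number from compound 1 to compound 4 (0.36 log units; beyond the scatter), a 2.2-fold lower number from compound 2 to compound 4 (0.34 log units; beyond the scatter) and a 2.1-fold lower number from compound 3 to compound 4 (0.31 log units; beyond the scatter), each modest but beyond the scatter and all in the same direction, so compound 4 separates from the other three as a group rather than from any single one of them. No measured evidence accounts for this separation.

As far as these compounds go, whether the lower number belongs to amino alone or extends to hydroxy, methylamino, dimethylamino or an acetamide at the same place remains open, as does whether a shorter alkoxy such as methoxy would stay level with butoxy. The compounds shown also leave open whether the amino step carries over to a change elsewhere on the shared core, for instance with the methoxy groups replaced, or to cell lines other than the one tested here.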